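Removing a Methyl from Compound 2: An Expected Outcome

The source may report more compounds than this note shows. Statements on the series, on what has been measured and on what is new or still open speak of the compounds shown alone.

Compound 2 `COc1ccc(/C=C/C(=O)c2cccc(-c3cccc(F)c3)c2)cc1OC` was tested in a functional assay on A549 cells (Homo sapiens) for cytotoxicity, read by sulforhodamine B assay, with a stated time of 48 h (a higher number here means a weaker inhibitor, a lower number a stronger inhibitor), where compound 2 gives 1940 nM. Compound 1 `COc1ccc(/C=C/C(=O)c2cccc(-c3cccc(F)c3)c2)cc1` gives 2440 nM, and the step of a 1.3-fold lower number from compound 1 to compound 2 (0.10 log units; within the scatter) leaves the pair within the scatter, so compound 2 stands alongside compound 1 rather than apart from it. Compound 3 `COc1cc(/C=C/C(=O)c2cccc(-c3cccc(F)c3)c2)ccc1O` differs from compound 2 by hydrogen in place of methyl on an oxygen on an aromatic ring. Among the measured compounds shown here, the one measured step puts methoxy in place of hydrogen on an aromatic carbon; no measured pair removes a methyl from an oxygen, so nothing here points in either direction. Compound 3 is therefore expected to give 2200 nM, between 1000 nM and 5000 nM, a step of a 1.1-fold higher number from compound 2 to compound 3 (0.05 log units; within the scatter) that stays within the scatter.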

Compound 3, half-maximal inhibitory concentration: 9900 nM
Estimate against measurement, compound 3: 4.5-fold (0.65 log units) below; measured number outside the range, above it.
By their numbers in this assay, from the lowest: compounds 2 and 1 (each within the scatter of the next); then compound 3.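

Methoxy to hydroxy, on an oxygen on an aromatic ring, gives the first step in this assay that lies beyond the scatter (a 5.1-fold higher number from compound 2 to compound 3 (0.71 log units; beyond the scatter)). The methyl on this oxygen therefore makes a measurable difference, whereas the earlier change, methoxy in place of hydrogen on an aromatic carbon, did not separate its pair (a 1.3-fold lower number from compound 1 to compound 2 (0.10 log units; within the scatter)). No measured information accompanies this result to explain the step. As far as these compounds go, whether a longer chain on this oxygen, such as ethyl, would behave like methyl or like hydrogen stays open. So does the outcome of an amine in place of the hydroxy.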